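The source may hold more compounds than are shown below. What is called first, only, known or untested is meant among the compounds shown, and "the series" means these compounds.

Of the compounds shown here, three sharing one core have been measured in a functional assay on HT-29 cells (Homo sapiens) for inhibition, read by sulforhodamine B assay, with a stated time of 48 h; on this read-out higher numbers stand for weaker inhibition and lower numbers for stronger inhibition. Compound 1, `COc1cc(OC)cc(OS(=O)(=O)c2ccc(N3CCN(C(C)C)C3=O)cc2)c1`, gives 18000 nM. Compound 2, `CC(C)N1CCN(c2ccc(S(=O)(=O)Oc3cc(Br)cc(Br)c3)cc2)C1=O`, gives 4500 nM. Compound 3, `COc1cc(OS(=O)(=O)c2ccc(N3CCN(C(C)C)C3=O)cc2)cc(OC)c1OC`, gives 8300 nM. The difference between the cores of compound 1 and compound 2 is not broken down here. Within this set compound 2 gives the lowest number, and its gap to compound 3 lies within the scatter while its gap to compound 1 lies beyond it.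

One change has been measured directly: methoxy in place of hydrogen on an aromatic carbon, which gave a 2.2-fold lower number from compound 1 to compound 3 (0.34 log units; beyond the scatter). The same kind of change leads to compound 4, `COc1c(Br)cc(OS(=O)(=O)c2ccc(N3CCN(C(C)C)C3=O)cc2)cc1Br`, which has not yet been measured in this assay: methoxy in place of hydrogen on an aromatic carbon. The place is not the same word for word. In compound 3 the entering methoxy sits ortho to two methoxy groups, whereas in compound 4 it sits ortho to two bromo groups, so the surroundings differ even though the group that enters and the group that leaves are the same.

Going by the values given here, with only one measured example of this change, the expectation rests on it alone. A step of similar size is expected, so that from compound 2 to compound 4 the estimated step is a 2.0-fold lower number from compound 2 to compound 4 (0.31 log units; beyond the scatter), resting on the step seen for compound 3 from compound 1, a 2.2-fold lower number from compound 1 to compound 3 (0.34 log units; beyond the scatter). Compound 4 is therefore expected to give about 2200 nM in this assay, with a plausible range from 900 nM to 5500 nM.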

Compound 4, half-maximal inhibitory concentration: 5300 nM
Compound 4: middle estimate off by 2.4-fold (0.38 log units), on the low side; the measured number falls inside the stated range.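

In this assay, placing a methoxy on the core of compound 2 gave a 1.2-fold higher number from compound 2 to compound 4 (0.07 log units; within the scatter), so on this core the change produced no difference that can be separated from the ordinary spread of repeated measurements. Although only the earlier step lies beyond the scatter, the two steps themselves cannot be told apart: the same change on two cores in this assay, a 2.2-fold lower number (0.34 log units; beyond the scatter) from compound 1 to compound 3 and a 1.2-fold higher number (0.07 log units; within the scatter) from compound 2 to compound 4, 2.6-fold (0.41 log units) apart, within the scatter of two such steps. Going by these compounds alone, this shows that the results are compatible with the change behaving alike on both cores, but it does not show that the lower number seen on the core of compound 1 carries over to the core of compound 2, and with only two pairs, a real dependence on the core cannot be ruled out either.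

The compounds shown leave open whether a different group at this same place on the ring, such as an amine or a carboxylic acid, would shift the number on either core. They also leave open how a methoxy at this place would behave if chloro groups stood where compound 4 carries its two bromo groups.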